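This account rests on a few compounds, and the source may have more. Where it says the series, first, only, none or still open, it means among the compounds named here.

Compound 1 `CC1(C)CCC[C@]2(C)[C@@H](CC[C@@](C)(O)/C=C/c3ccccc3)[C@](C)(O)CC[C@@H]12`: 3320 nM
Compound 2 `CC1(C)CCC[C@]2(C)[C@@H](CC[C@@](C)(O)/C=C/c3ccc(Cl)nc3)[C@](C)(O)CC[C@@H]12`: 3680 nM

Both values come from a functional assay on HeLa cells (Homo sapiens) for cytotoxicity, read by MTT assay, with a stated time of 48 h; on this read-out higher numbers stand for weaker inhibition and lower numbers for stronger inhibition. Among the compounds with values here, with only two compounds measured, compound 2 stands level with compound 1, since the step of a 1.1-fold higher number from compound 1 to compound 2 (0.04 log units; within the scatter) is too small to separate them. Within the data shown here, that step is also the only measured evidence for the next change. It replaced one aromatic group with another at the same place on the chain, and the reading did not move beyond the scatter.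

Compound 3 `CC(C)(C)c1ccc(/C=C/[C@](C)(O)CC[C@@H]2[C@@]3(C)CCCC(C)(C)[C@@H]3CC[C@@]2(C)O)cc1` has not yet been measured. It keeps the shared core and the chain and differs from compound 2 only in the aromatic group: 4-(tert-butyl)phenyl in place of 6-chloropyridin-3-yl on a double-bonded chain carbon bound to a double-bonded chain carbon. Among the measured compounds shown here, no measured compound carries the 4-(tert-butyl)phenyl group, so a single earlier swap is a thin guide, and a wide range is needed. Going by that swap, no change beyond the scatter is expected in this assay, and the expected step is a 1.1-fold lower number from compound 2 to compound 3 (0.02 log units; within the scatter). For compound 3 the estimated value is 3500 nM, with an expected range from 1500 nM to 8000 nM.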

Compound 3, half-maximal inhibitory concentration: 48500 nM
Estimate against measurement, compound 3: 14-fold (1.14 log units) below; the whole stated range lies below it.
By their numbers in this assay, from the lowest: compounds 1 and 2 (each within the scatter of the next); then compound 3.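

In this assay this place on the chain turns out to be sensitive to the choice of aromatic group. The earlier swap of phenyl for 6-chloropyridin-3-yl stayed within the scatter, but 4-(tert-butyl)phenyl gives a 13-fold higher number from compound 2 to compound 3 (1.12 log units; beyond the scatter) and so a clear loss of strength. The comparison with the plain phenyl ring is the cleanest one, since tert-butyl in place of hydrogen on an aromatic carbon is the only difference and it gives a 15-fold higher number from compound 1 to compound 3 (1.16 log units; beyond the scatter) in the same direction. No measurement is available that would explain this loss.

The three compounds do not show whether a smaller group on the same ring, such as methyl or methoxy, would leave the number close to that of compound 1 or would already raise it. They also leave open how a ring carrying an amine or a carboxylic acid in place of the tert-butyl group would read, and whether the same loss would appear in cells other than the HeLa line.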